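This account rests on a few compounds, and the source may have more. Where it says the series, first, only, none or still open, it means among the compounds named here.

Measured compounds in an assay on isolated protein for inhibition of DNA topoisomerase 1 (Homo sapiens), with a stated time of 30 min, tested at 100 uM; on this read-out higher numbers stand for more inhibition at the one concentration tested (going by the name of the read-out) and lower numbers for less inhibition:

- compound 1 `Oc1cccc(-c2cc(-c3cccc(O)c3)nc(-c3ccccc3O)c2)c1`: 1.9%
- compound 2 `Oc1cccc(-c2cc(-c3ccccc3O)cc(-c3cccc(O)c3)n2)c1`: 0%
- compound 3 `Oc1ccc(-c2cc(-c3ccccc3O)cc(-c3ccccc3O)n2)cc1`: 0.3%

All three numbers in this assay sit at the bottom of the read-out. Compound 3 gives the second highest of the three, with compound 2 nearest and compound 1 furthest; both gaps lie within the scatter of this kind of measurement, so no order among compounds 1, 2 and 3 can be read from them. In effect the series shows no inhibition at the concentration tested.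

Compound 4 `Oc1cccc(-c2cc(-c3ccccc3O)cc(-c3ccccc3O)n2)c1` has not been measured. It differs from compound 3 in one place: 3-hydroxyphenyl in place of 4-hydroxyphenyl on an aromatic carbon. The change sits next to the ring nitrogen, meta to two 2-hydroxyphenyl groups.

Going by the values given here, no step between measured compounds is available to guide the expectation. Since compound 1, compound 2 and compound 3 all lie within the scatter of one another at the floor of the read-out, the step of a number 1.2 percentage points higher from compound 3 to compound 4 (within the scatter) is expected to be none beyond the scatter. Compound 4 is expected to give 1.5% in this assay, with a range from 0% to 9%.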

Compound 4, a percentage reported as inhibition, at one concentration (the size of the read-out at that concentration, not a potency): 0%
Compound 4: middle estimate off by 1.5 percentage points, on the high side, and the stated range covers the measured number.
By their numbers in this assay, from the lowest: compounds 2, 4, 3 and 1 (each within the scatter of the next).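

In this assay, going by these compounds alone, 3-hydroxyphenyl in place of 4-hydroxyphenyl next to the ring nitrogen gives a number 0.3 percentage points lower from compound 3 to compound 4 (within the scatter) and so offers the first direct reading at this position: this swap of hydroxyphenyl groups produces no change beyond the scatter. The exchanges of 2-hydroxyphenyl for 3-hydroxyphenyl on an aromatic carbon read the same way, with no change at the digits printed from compound 2 to compound 4 (within the scatter) and a number 1.9 percentage points lower from compound 1 to compound 4 (within the scatter) so all three steps to compound 4 stay at the bottom of the read-out. No independent measurement is available to bear on this result.

With every number this close to the bottom of the read-out, the steps cannot show whether the hydroxyl placement matters once inhibition is present. On these data alone, what an amine or a carboxylic acid would give in place of the hydroxyl on this ring remains open.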